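This account rests on a few compounds, and the source may have more. Where it says the series, first, only, none or still open, it means among the compounds named here.

Measured in a functional assay on SK-OV-3 cells (Homo sapiens) for antiproliferative activity, read by MTT assay, with a stated time of 24 h; a higher number here means a weaker inhibitor, a lower number a stronger inhibitor:
- compound 1 `COc1cccc(/C=C/C(=O)c2ccc(OC)c3c2OC(C)(C)C=C3)c1`: 9360 nM
- compound 2 `COc1ccc(C(=O)/C=C/c2ccc3ccccc3c2)c2c1C=CC(C)(C)O2`: 7650 nM
- compound 3 `COc1ccc(C(=O)/C=C/c2ccc3ccccc3n2)c2c1C=CC(C)(C)O2`: 2350 nM

Compound 1 has the highest number of the three in this assay. Compound 2 stands within the scatter of compound 1, so the two cannot be ranked against each other. Among the compounds with values here, compound 3 gives a lower number than compound 1, and that gap lies beyond the scatter; no single-change step connects the two, so only the two values themselves can be compared.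

Compound 4 `COc1ccc(C(=O)/C=C/c2cccc(Cl)c2)c2c1C=CC(C)(C)O2` has not yet been measured. It differs from compound 1 in one place: chloro in place of methoxy on an aromatic carbon. The change sits on an aromatic carbon of a six-membered aromatic ring of carbon only. Within the data shown here, no measured pair carries this same change, so there is no step to lean on, and the expectation is kept close to compound 1 with a wide range. A step from compound 1 to compound 4 of about a 1.6-fold lower number from compound 1 to compound 4 (0.19 log units; within the scatter) in this assay is expected, toward a somewhat lower number but not clearly beyond the scatter. For compound 4 the estimate is 6000 nM in this assay, with a range from 2500 nM to 14000 nM.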

Compound 4, half-maximal inhibitory concentration: > 10000 nM
Compound 4: no number, only a limit; the forecaster's own chance of this, stated with the estimate: 5%; middle value at least 1.6-fold (0.22 log units) from the limit.
By their numbers in this assay, from the lowest: compound 3; then compounds 2 and 1 (each within the scatter of the next). At a limit, above all of these: compound 4.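

Compound 4 gives a limit and not a number in this assay: the limit of > 10000 nM in this assay, at which 1 of the 4 values shown sits.

Chloro in place of methoxy on an aromatic carbon, meta to a large group, is the only single-place change among the compounds shown, and it reads as an at least 1.0-fold higher number from compound 1 to compound 4 (0.02 log units; that floor lies within the scatter). Only that floor is known, so the step gives no sign of a lower number with chloro at this place, and its true size cannot be read.

Still open, from the compounds shown here alone, is how this place responds to groups other than methoxy and chloro, for instance an amine, a hydroxyl or a carboxylic acid in place of 3-methoxy on the phenyl ring. One change at one place also says nothing about whether the same swap would behave alike on another aromatic carbon of the compound.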